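Carbonyl substituent survey on the shared core, compounds 1 to 4

The compounds below may be only part of what the source reports. "The series", "measured", "known", "first", "only" and "open" are said of these compounds alone.

Measured so far:
compound 1, `CCCCN1CCc2nc(C#Cc3ccccc3)sc2C1`: 110 nM
compound 2, `CCC(=O)N1CCc2nc(C#Cc3ccccc3)sc2C1`: > 10000 nM
compound 3, `CC1CC1C(=O)N1CCc2nc(C#Cc3ccccc3)sc2C1`: 9.4 nM

In an assay on HEK293 cells for positive allosteric modulation of metabotropic glutamate receptor 5 (Homo sapiens), read by FLIPR, with a stated time of 1 h (on this read-out lower numbers stand for an effect already at smaller amounts and higher numbers for an effect only at larger amounts of compound), compound 1 gives 110 nM. Compound 2 is reported only as a limit of this assay, > 10000 nM (the limit of > 10000 nM in this assay, at which 1 of the 3 values shown sits). Compound 3 gives 9.4 nM, the lowest of the two numbers; its nearest neighbour is compound 1, with a 12-fold lower number from compound 1 to compound 3 (1.07 log units; beyond the scatter). The amide members differ sharply among themselves: an at least 90-fold higher number from compound 1 to compound 2 (1.95 log units; beyond the scatter), whereas an at least 1000-fold lower number from compound 2 to compound 3 (3.02 log units; beyond the scatter).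

Compound 4, `O=C(C1CCCO1)N1CCc2nc(C#Cc3ccccc3)sc2C1`, is not yet measured. It differs from compound 3 in that (oxolan-2-yl in place of 2-methylcyclopropyl on a carbonyl carbon). For the measured compounds named here, the step that bears on it is an at least 1000-fold lower number from compound 2 to compound 3 (3.02 log units; beyond the scatter), which shows that the group on the carbonyl carbon moves the read-out over a very wide span; no measured member carries a ring with a hetero atom at this position, so the direction rests on that one step alone. A higher number than for compound 3 is expected, an 11-fold higher number from compound 3 to compound 4 (1.03 log units; beyond the scatter), with wide uncertainty. Compound 4 is estimated at 100 nM, range 15 nM to 2000 nM.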

Compound 4, half-maximal effective concentration: 790 nM
Estimate against measurement, compound 4: 7.9-fold (0.90 log units) below; low and high end bracket the measured number.
By their numbers in this assay, from the lowest: compound 3; then compound 1; then compound 4. At a limit, above all of these: compound 2.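

Within this assay, a ring on the carbonyl carbon does not by itself secure the low number of compound 3: the change to oxolan-2-yl gives an 84-fold higher number from compound 3 to compound 4 (1.92 log units; beyond the scatter). The oxolan-2-yl amide still reads clearly better than the ethyl amide, an at least 12-fold lower number from compound 2 to compound 4 (1.10 log units; beyond the scatter), although this step is open-ended, with compound 2 reported only as a limit of the assay: the limit of > 10000 nM in this assay, at which 1 of the 4 values shown sits. The amide carbonyl also does not fix the order against the butyl amine: compound 3 lies lower than compound 1, whereas the oxolan-2-yl amide gives a 7.2-fold higher number from compound 1 to compound 4 (0.86 log units; beyond the scatter).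

Which feature of the oxolan-2-yl ring goes with the rise stays open, since its ring size and its oxygen both differ from 2-methylcyclopropyl. Cyclopentyl and plain cyclopropyl on the carbonyl carbon would separate these two differences and the role of the methyl.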